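Replacing a dimethoxyphenyl with thiophene on the pyridine core

This account rests on a few compounds, and the source may have more. Where it says the series, first, only, none or still open, it means among the compounds named here.

Measured so far:
- compound 1, `CC(C(=O)NCc1ccc(C(F)(F)F)nc1-c1ccc(N(C)C)cc1)c1ccc(NS(C)(=O)=O)c(F)c1`: 3.2 nM
- compound 2, `COc1ccc(-c2nc(C(F)(F)F)ccc2CNC(=O)C(C)c2ccc(NS(C)(=O)=O)c(F)c2)cc1F`: 4.2 nM
- compound 3, `COc1ccc(-c2nc(C(F)(F)F)ccc2CNC(=O)C(C)c2ccc(NS(C)(=O)=O)c(F)c2)cc1OC`: 25.6 nM

All three were tested in an assay on CHO cells for antagonist activity at transient receptor potential cation channel subfamily V member 1 (Homo sapiens), read by FLIPR; a higher number here means a weaker inhibitor, a lower number a stronger inhibitor. Compound 3 gives the highest number of the three: the step of an 8.0-fold higher number from compound 1 to compound 3 (0.90 log units; beyond the scatter) and the step of a 6.1-fold higher number from compound 2 to compound 3 (0.78 log units; beyond the scatter) both lie beyond the scatter, so compound 3 is the weakest inhibitor here. Compounds 1 and 2 differ only within the scatter, as a 1.3-fold higher number from compound 1 to compound 2 (0.12 log units; within the scatter) shows.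

Compound 4, `CC(C(=O)NCc1ccc(C(F)(F)F)nc1-c1ccsc1)c1ccc(NS(C)(=O)=O)c(F)c1`, arises from compound 3 by one change: thiophen-3-yl in place of 3,4-dimethoxyphenyl on an aromatic carbon. Among the compounds with values here, no measured step swaps this whole aryl group for a small five-membered ring, so the guidance is indirect. What the data do show is that the 3,4-dimethoxyphenyl group in compound 3 is the least favourable of the three aryl groups tried, and that both alternatives gave lower numbers. Removing it in favour of a much smaller ring therefore seems more likely to lower the number than to raise it, though the size of any gain is uncertain and could also be nil.

Compound 4 is expected to give 9 nM in this assay, within 2.5 nM to 35 nM, a step of a 2.8-fold lower number from compound 3 to compound 4 (0.45 log units; beyond the scatter) that is estimated, not measured.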

Compound 4, inhibition constant: 2 nM
For compound 4 the middle estimate is 4.5-fold (0.65 log units) above the measured one; measured number below the stated range.
By their numbers in this assay, from the lowest: compounds 4, 1 and 2 (each within the scatter of the next, the first and the last beyond it); then compound 3.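

The position next to the ring nitrogen does not need a six-membered aromatic ring: in this assay, thiophen-3-yl, with fewer heavy atoms than 3,4-dimethoxyphenyl, gives the largest step in this set (a 13-fold lower number from compound 3 to compound 4 (1.11 log units; beyond the scatter)). The smaller ring also compares well with the other two aryl groups, with a modest step against 3-fluoro-4-methoxyphenyl (a 2.1-fold lower number from compound 2 to compound 4 (0.32 log units; beyond the scatter)), whereas the comparison with 4-(dimethylamino)phenyl (a 1.6-fold lower number from compound 1 to compound 4 (0.20 log units; within the scatter)) stays within the scatter, so thiophen-3-yl and that group cannot be told apart here. Nothing measured for these compounds explains why these aryl groups differ.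

The swap in compound 4 alters the ring size, the ring atoms and the substituents all at once, so the compounds shown leave open which of these changes accounts for the step, and an unsubstituted phenyl, a thiophen-2-yl or a furan-3-yl ring at the same carbon would help to separate them. They also leave open whether this position needs an aromatic ring at all, a question that a saturated amine such as morpholine or a simple alkyl chain in place of the ring could address.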